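Side chain change from compound 2 to compound 3

This account rests on a few compounds, and the source may have more. Where it says the series, first, only, none or still open, it means among the compounds named here.

Values in a functional assay on HCT-15 cells (Homo sapiens) (on this read-out higher numbers stand for an effect only at larger amounts of compound and lower numbers for an effect already at smaller amounts), for the measured compounds:
- compound 1 `CCOC(=O)C(=O)N1N=C(c2ccc(N(C)C)cc2)OC1c1cc(OC)c(OC)c(OC)c1` gives 45 uM
- compound 2 `COc1cc(C2OC(c3ccc(N(C)C)cc3)=NN2C(=O)COC(C)=O)cc(OC)c1OC` gives 0.019 uM

Compound 2 has the lower of the two numbers. Compound 3 `COc1cc(C2OC(c3ccc(N(C)C)cc3)=NN2C(=O)CN)cc(OC)c1OC` differs from it by amino in place of acetoxy on a saturated chain carbon bound to a carbonyl carbon, with amino in place of acetoxy on a saturated chain carbon bound to a carbonyl carbon. Going by the values given here, the only measured step, a 2400-fold lower number from compound 1 to compound 2 (3.37 log units; beyond the scatter), was large and also changed the group on a carbonyl carbon, but it gives no direction for amino. A higher number is expected, by less than that step. The expected change is a 7.9-fold higher number from compound 2 to compound 3 (0.90 log units; beyond the scatter). For compound 3 the estimate is 0.15 uM, with an expected range from 0.01 uM to 3 uM.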

Compound 3, concentration for half-maximal effect: 0.65 uM
Estimate against measurement, compound 3: 4.3-fold (0.64 log units) below; the range from low to high includes it.
By their numbers in this assay, from the lowest: compound 2; then compound 3; then compound 1.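

In this assay, the saturated chain carbon bound to a carbonyl carbon is sensitive to its substituent: amino in place of acetoxy gives a 34-fold higher number from compound 2 to compound 3 (1.53 log units; beyond the scatter) and so loses part of the earlier gain. Even so, the gain does not depend on acetoxymethyl alone, since aminomethyl in place of ethoxycarbonyl gives a 69-fold lower number from compound 1 to compound 3 (1.84 log units; beyond the scatter) as a large step in the same direction as the acetoxymethyl change. No supporting data explain the difference between acetoxy and amino.

Open, from the compounds shown here alone, is how hydroxy, dimethylamino or acetamido would behave on this chain carbon. Going by these compounds, a longer chain carrying the amine is also open.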